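A hydroxy group on a compound at the limit

The source may hold more compounds than are shown below. What is called first, only, known or untested is meant among the compounds shown, and "the series" means these compounds.

In an ADME assay on microsomes from liver (Homo sapiens) for metabolic stability, read by LC-MS, using NADPH (a lower number here means that the compound disappears faster, a higher number that the compound lasts longer), compound 1 (`CCC(C)(C)C(=O)NCc1ccccc1`) gives > 3.33 h as a limit of the assay, not a number. Compound 2 (`CCC(C)(C)C(=O)NC(C)c1ccccc1`) gives > 3.33 h as a limit too, so its place is known only as a limit. For the measured compounds named here, both sit at the same limit (the limit of > 3.33 h in this assay, at which 2 of the 2 values shown sit), and the one measured step (a step that the two limits leave unreadable from compound 1 to compound 2) has no readable size. Compound 3 (`CCC(C)(C)C(=O)NC(CO)c1ccccc1`) differs from compound 2 by hydroxy in place of hydrogen on a saturated chain carbon, two bonds along the chain from an amide-type nitrogen and an aromatic carbon, which also reads methyl to hydroxymethyl. Going by the values given here, no measured step gives a size for this change, so in this assay no step beyond the scatter is expected, in either direction. The expected step (a number no higher from compound 2 to compound 3 (the limit leaves the size open)) is a rough estimate that starts from the limit of compound 2 (> 3.33 h) and not from a number. For compound 3 the estimate is 3.3 h (expected range 1.5 h to 6 h), quite possibly reported again as a limit.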

Compound 3, half-life: > 3.33 h
Compound 3 was reported as a limit; the forecaster's own chance of this, stated with the estimate: 60%; at least 1.0-fold (0.00 log units) between middle value and limit.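

Compound 3 was reported as a limit, as were compound 1 and compound 2, so no step among these compounds can be read: the limit of > 3.33 h in this assay, at which 3 of the 3 values shown sit.

The compounds shown leave open how long any of the three actually lasts in this assay, and whether hydroxy in place of hydrogen changes that half-life at all.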